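Swapping Benzyl for 3-Chlorophenyl: An Expected Potency

The source may hold more compounds than are shown below. What is called first, only, known or untested is meant among the compounds shown, and "the series" means these compounds.

Measured compounds:
compound 1 `O=C1C=C(NCc2ccccc2)C(=O)c2c1nc1n2[C@H]2OC[C@@H](O)[C@H]2OC1` gives 2670 nM
compound 2 `O=C1C(Nc2ccccc2)=CC(=O)c2c1nc1n2[C@H]2OC[C@@H](O)[C@H]2OC1` gives 1830 nM
compound 3 `CCOc1ccc(NC2=CC(=O)c3c(nc4n3[C@H]3OC[C@@H](O)[C@H]3OC4)C2=O)cc1` gives 2090 nM

These three share one core and differ only in the group on the amine nitrogen. In a functional assay on MGC-803 cells (Homo sapiens) for inhibition, read by sulforhodamine B assay (a lower number here means a stronger inhibitor, a higher number a weaker inhibitor), compound 1 gives 2670 nM, the highest of the three numbers, though its gaps to compound 3 and to compound 2 both lie within the scatter, so no order among them can be claimed.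

The unmeasured compound 4 `O=C1C=C(Nc2cccc(Cl)c2)C(=O)c2c1nc1n2[C@H]2OC[C@@H](O)[C@H]2OC1` arises from compound 1 by the change (3-chlorophenyl in place of benzyl on an amine nitrogen). Among the measured compounds shown here, no measured step covers this exact change. For the measured compounds named here, the one measured step, a 1.1-fold higher number from compound 2 to compound 3 (0.06 log units; within the scatter), shows that adding ethoxy to the aromatic ring changed nothing beyond the scatter. Compounds 1 and 2, which differ in a benzyl against a phenyl group, also give numbers within the scatter of each other. Nothing here points to a shift in either direction, so a step of no consequence is expected in this assay.

Compound 4 is therefore estimated at 1900 nM, within 700 nM to 5000 nM. The step expected is a 1.4-fold lower number from compound 1 to compound 4 (0.15 log units; within the scatter), because compound 1 gives 2670 nM.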

Compound 4, half-maximal inhibitory concentration: 1770 nM
For compound 4 the middle estimate is 1.1-fold (0.03 log units) above the measured one, within the range that was stated.
By their numbers in this assay, from the lowest: compounds 4, 2, 3 and 1 (each within the scatter of the next).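

On this amine nitrogen of the shared core, putting 3-chlorophenyl in place of benzyl gives a 1.5-fold lower number from compound 1 to compound 4 (0.18 log units; within the scatter) in this assay, so this exchange cannot be told apart from repeat-measurement noise. Among the compounds shown here, this is the first direct reading of the exchange, and it shows that a chlorine-bearing aromatic ring attached straight to the nitrogen leaves the cell result in the same range as benzyl, with the same count of heavy atoms in both groups. No measurement of any property of these groups accompanies this result, and with a step this small there is no shift to account for.

On these data alone, all the groups on this nitrogen so far carry a carbon-only aromatic ring, so it remains open whether any group here can move the number beyond the scatter, for example a longer chain ending in an amine, a morpholine ring, or a carboxylic acid on the aromatic ring. For the compounds shown here, the single step also changes two things at once, the chlorine and the loss of the benzyl carbon, and a one-place comparison of each alone would be needed to read them separately.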